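Amino for Methyl on a Shared Nucleoside Core

The compounds below may be only part of what the source reports. "The series", "measured", "known", "first", "only" and "open" are said of these compounds alone.

Measured so far:
Compound 1, `Nc1nc(N)c2c(-c3ccsc3)cn([C@@H]3O[C@H](CO)[C@@H](O)[C@H]3O)c2n1`: in a functional assay on HCT-116 cells (Homo sapiens), read by MTT assay, with a stated time of 72 h (a higher number here means a weaker inhibitor, a lower number a stronger inhibitor), compound 1 gives > 20000 nM, which is a limit of the assay and not a number.
Compound 2, `COc1nc(N)nc2c1c(-c1ccccc1)cn2[C@@H]1O[C@H](CO)[C@@H](O)[C@H]1O`: in this assay compound 2 gives > 20000 nM, again a limit.
Compound 3, `Cc1nc(N)c2c(-c3ccccc3)cn([C@@H]3O[C@H](CO)[C@@H](O)[C@H]3O)c2n1`: in this assay compound 3 gives > 20000 nM, also a limit.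

Compound 3 therefore has no fixed place on the numbers shown: its result is a limit, and the limit of > 20000 nM in this assay, at which 3 of the 3 values shown sit, shows that every measured compound so far has ended the same way. Going by the values given here, no two measured compounds differ in a single place, so there is no measured step to lean on. The next compound to be measured is compound 4, `Nc1nc(N)c2c(-c3ccccc3)cn([C@@H]3O[C@H](CO)[C@@H](O)[C@H]3O)c2n1`. It differs from compound 3 by amino in place of methyl on an aromatic carbon. Compound 1 already carries an amino group at that place, and in this assay compound 1 gives > 20000 nM, a limit. On this basis the step expected in this assay is a number no higher from compound 3 to compound 4 (the limit leaves the size open), which is none beyond the scatter. Compound 4 is estimated at 20000 nM, between 5000 nM and 60000 nM, and it is expected that the assay will most likely again report only a limit.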

Compound 4, half-maximal inhibitory concentration: > 20000 nM
Compound 4: a limit, no number; the forecaster's own chance of this, stated with the estimate: 85%; the middle value sits exactly at the limit.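

Compound 4 ends at a limit and not at a number, like compound 1, compound 2 and compound 3, so none of the steps joining it to those three can be read: the limit of > 20000 nM in this assay, at which 4 of the 4 values shown sit. The compounds shown leave open how strongly any of the four acts in this assay, and whether amino, methyl, methoxy, phenyl or thiophen-3-yl makes any difference there.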